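This account rests on a few compounds, and the source may have more. Where it says the series, first, only, none or still open, it means among the compounds named here.

Measured so far:
- compound 1 `CCCCCCCCCCCCCCNc1nc(=O)c2ncn([C@@H]3O[C@H](CO)[C@@H](O)[C@H]3O)c2c(=O)[nH]1` – 30 ug/mL
- compound 2 `CCCCCCCCCCCCNc1nc(=O)c2c(ncn2[C@H]2C[C@H](O)[C@@H](CO)O2)c(=O)[nH]1` – > 500 ug/mL

In an assay on isolated protein for inhibition of ATP-dependent RNA helicase SUPV3L1, mitochondrial (Homo sapiens) (a higher number here means a weaker inhibitor, a lower number a stronger inhibitor), compound 1 gives 30 ug/mL. For compound 2 only a limit is known: it sits at the limit of > 500 ug/mL in this assay, at which 1 of the 2 values shown sits, so no number is available for it, only a floor. Among the measured compounds shown here, no step between compound 1 and compound 2 is counted here; the two structures differ in more than one place, and their values show only that compound 1 has a number while compound 2 does not.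

Compound 3 `CCCCCCCCCCCCNc1nc(=O)c2c(ncn2Cc2ccc(OC)cc2)c(=O)[nH]1` is not yet measured in this assay. It differs from compound 2 in one place: 4-methoxybenzyl in place of 4-hydroxy-5-(hydroxymethyl)oxolan-2-yl on an aromatic nitrogen. With compound 2 at a limit, the step can only be bounded from one side; the expected step of an at least 1.4-fold lower number from compound 2 to compound 3 (0.15 log units; that floor lies within the scatter) is small, with no clear direction beyond the scatter. For compound 3 the estimate in this assay is 350 ug/mL, expected between 100 ug/mL and 1200 ug/mL, with a fair chance that again only a limit is reported.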

Compound 3, half-maximal inhibitory concentration: > 500 ug/mL
Compound 3 was reported as a limit; the forecaster's own chance of this, stated with the estimate: 55%; middle value at least 1.4-fold (0.15 log units) away from the limit.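

Compound 2 and compound 3 are both reported only as limits in this assay, so no step between them can be read: the limit of > 500 ug/mL in this assay, at which 2 of the 3 values shown sit.

The compounds shown leave open whether 4-methoxybenzyl and 4-hydroxy-5-(hydroxymethyl)oxolan-2-yl on the aromatic nitrogen differ at all in this assay.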